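The source may hold more compounds than are shown below. What is called first, only, known or untested is meant among the compounds shown, and "the series" means these compounds.

Measured compounds:
compound 1 `Cc1nc(-c2ccc(Cl)cc2)sc1C1SCC(=O)N1c1ccc(F)c(Cl)c1` gives 53.4% in a functional assay on the whole organism (strain Wistar albino) for inhibition, with Rattus norvegicus as the target, read by paw edema, with a stated time of 1 h, at a dose of 40 mg/kg by the oral route; on this read-out lower numbers stand for less inhibition and higher numbers for more inhibition at the one dose given (going by the name of the read-out);
compound 2 `Cc1nc(Cc2ccc(Cl)cc2)sc1C1SCC(=O)N1c1ccc(F)c(Cl)c1` gives 40.7% in this assay.

Within the data shown here, the one measured step, a number 12.7 percentage points lower from compound 1 to compound 2 (beyond the scatter), leaves compound 2 with the lower of the two numbers in this assay. Compound 3 `Cc1ccc(N2C(=O)CSC2c2sc(Cc3ccc(Cl)cc3)nc2C)cc1` keeps the whole of compound 2 apart from one change: 4-methylphenyl in place of 3-chloro-4-fluorophenyl on an amide-type nitrogen in a ring. Among the measured compounds shown here, no measured step touches this position; the only step on record concerns a different place in the shared core, so it gives no direct guide to the size or direction of the change from compound 2 to compound 3. With nothing to indicate a shift, the expectation is a step of a number 2.7 percentage points lower from compound 2 to compound 3 (within the scatter), not beyond the scatter, for compound 3 in this assay. Compound 3 is therefore estimated at 38%, within a range from 22% to 54%.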

Compound 3, a percentage reported as inhibition, in the whole organism at one dose (the size of the read-out at that dose, not a potency): 59.9%
For compound 3 the middle estimate is 21.9 percentage points below the measured one; the whole stated range lies below it.
By their numbers in this assay, from the lowest: compound 2; then compounds 1 and 3 (each within the scatter of the next).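

In this assay, the group on the amide-type nitrogen in a ring proves able to move the read-out: 4-methylphenyl in place of 3-chloro-4-fluorophenyl gives a number 19.2 percentage points higher from compound 2 to compound 3 (beyond the scatter), with the 4-chlorobenzyl group and the rest of the structure unchanged. Among these compounds, this is the first sign that this position, untouched by the earlier step, matters in its own right, and that a ring carrying fluorine and chlorine is not needed there for the higher number. Nothing available accounts for the size or direction of this step.

Since the change removes fluorine and chlorine and adds a methyl group at once, the compounds shown do not separate the share of each. Going by these compounds, it also remains open how an unsubstituted phenyl, a 4-methoxyphenyl or a 4-aminophenyl group would read at this position, or whether 4-methylphenyl would give a similar step alongside the 4-chlorophenyl group of compound 1.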